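Moving the Hydroxy Group to a Different Place

This account rests on a few compounds, and the source may have more. Where it says the series, first, only, none or still open, it means among the compounds named here.

Three compounds have been measured in a toxicity assay on WI-38 cells (Homo sapiens) for cytotoxicity, read by MTT assay, with a stated time of 48 h; a lower number here means a stronger inhibitor, a higher number a weaker inhibitor:
compound 1, `O=C(/C=C/c1ccc2c(c1)B(O)OC2)c1ccccc1`: 19100 nM
compound 2, `O=C(/C=C/c1ccc2c(c1)B(O)OC2)c1ccc(F)cc1`: 7600 nM
compound 3, `O=C(/C=C/c1ccc2c(c1)B(O)OC2)c1ccc(O)cc1`: reported only as an assay limit, > 100000 nM

Among the numbers shown, compound 1 gives the highest; compound 2 is nearest, at a 2.5-fold lower number from compound 1 to compound 2 (0.40 log units; beyond the scatter). Compound 4, `O=C(/C=C/c1ccc2c(c1)B(O)OC2)c1ccccc1O`, is still to be measured, and it differs from compound 1 by hydroxy in place of hydrogen on an aromatic carbon. The same kind of change, hydroxy in place of hydrogen on an aromatic carbon, is already seen in the step from compound 1 to compound 3, which read an at least 5.2-fold higher number from compound 1 to compound 3 (0.71 log units; beyond the scatter), and hydroxy in place of fluoro read an at least 13-fold higher number from compound 2 to compound 3 (1.11 log units; beyond the scatter). A higher number is therefore expected for compound 4 as well, estimated at a 2.6-fold higher number from compound 1 to compound 4 (0.42 log units; beyond the scatter). Compound 4 is thus expected to give 50000 nM, within 15000 nM to 120000 nM.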

Compound 4, half-maximal inhibitory concentration: > 100000 nM
Compound 4 ended at the assay's limit (the forecaster's own chance of this, stated with the estimate: 35%); at least 2.0-fold (0.30 log units) between middle value and limit.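

In this assay, hydroxy ortho to a large group gives an at least 5.2-fold higher number from compound 1 to compound 4 (0.71 log units; beyond the scatter), and the gap to the fluoro analogue is an at least 13-fold higher number from compound 2 to compound 4 (1.11 log units; beyond the scatter). The rise seen with 4-hydroxyphenyl is therefore not tied to that one place on the ring, as 2-hydroxyphenyl shows it too. The step between the two hydroxy compounds cannot be read, because both stand at a limit: the limit of > 100000 nM in this assay, at which 2 of the 4 values shown sit.

On these data alone, how far beyond that limit either compound lies stays open. So does whether a methoxy group or an amine on the same ring would also raise the number.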